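Cytotoxicity estimate for a methylpiperazine analogue of compound 1

The source may hold more compounds than are shown below. What is called first, only, known or untested is meant among the compounds shown, and "the series" means these compounds.

Compound 1 `CC(C)N(C)c1nc(Cc2c(F)cccc2F)cc(=O)[nH]1` — 85000 nM
Compound 2 `CC1CCCN(c2nc(Cc3c(F)cccc3F)cc(=O)[nH]2)C1` — a limit, > 78000 nM

Among the compounds with values here, in an ADME assay on MT4 cells (Homo sapiens) for cytotoxicity, read by MTT assay, with a stated time of 4 days (a lower number here means that less compound is tolerated, a higher number that more compound is tolerated), compound 1 gives 85000 nM, the only plain number measured here. For compound 2 the result is a limit, > 78000 nM. The step that the limit leaves unreadable from compound 1 to compound 2 is therefore not readable, as the limit of > 78000 nM in this assay, at which 1 of the 2 values shown sits, shows. Compound 3 `CN1CCN(c2nc(Cc3c(F)cccc3F)cc(=O)[nH]2)CC1` carries the change (4-methylpiperazin-1-yl in place of isopropyl(methyl)amino on an aromatic carbon). Within the data shown here, no measured step bears on this change, so no shift beyond the scatter is expected. Compound 3 is estimated at 90000 nM, with a range from 40000 nM to 200000 nM. This estimate means an expected step of a 1.1-fold higher number from compound 1 to compound 3 (0.02 log units; within the scatter).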

Compound 3, half-maximal cytotoxic concentration: > 78000 nM
Compound 3: a limit, no number (the forecaster's own chance of this, stated with the estimate: 50%); the middle value does not contradict the limit.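

Within the data shown here, for compound 3, this assay gives the limit > 78000 nM and no number, so no new step from compound 1 or compound 2 to compound 3 can be read. The compounds shown leave open how far compound 2 and compound 3 lie from compound 1: the limit of > 78000 nM in this assay, at which 2 of the 3 values shown sit.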